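Swapping the aryl group on the shared core of compound 3

This account rests on a few compounds, and the source may have more. Where it says the series, first, only, none or still open, it means among the compounds named here.

Of the compounds shown here, three have been tested in a functional assay on HT-29 cells (Homo sapiens) for cytotoxicity, read by MTT assay, with a stated time of 72 h; a higher number here means a weaker inhibitor, a lower number a stronger inhibitor. Compound 1 `Fc1ccc(Nc2cc(Nc3ccc(Oc4ccncc4-c4cccnc4)c(F)c3)ncn2)cc1F` gives 2320 nM, and compound 2 `Cn1c(=O)c(C(=O)Nc2ccc(Oc3ccncc3-c3cccnc3)c(F)c2)nn(-c2ccccc2F)c1=O` gives 2100 nM. Compound 3 `Cn1c(=O)c(C(=O)Nc2ccc(Oc3ccncc3-c3cccnc3)c(F)c2)nn(-c2cccc(C(F)(F)F)c2)c1=O` gives 510 nM, the lowest of the three numbers: compound 2 sits a step above it, and compound 1 sits a little further above, both steps beyond the scatter. The one single-point step among these is a 4.1-fold lower number from compound 2 to compound 3 (0.61 log units; beyond the scatter), which shows that the group on the aromatic nitrogen matters for this assay.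

Compound 4 `Cn1c(=O)c(C(=O)Nc2ccc(Oc3ccncc3-c3cccnc3)c(F)c2)nn(-c2ccc(F)c(Cl)c2)c1=O` keeps the whole of compound 3 except for that group: 3-chloro-4-fluorophenyl in place of 3-(trifluoromethyl)phenyl on an aromatic nitrogen. A 3-chloro-4-fluorophenyl group, like the 3-(trifluoromethyl)phenyl it replaces, carries a substituent at the 3-position, but it is a different one, so the outcome is not fixed by the earlier step. Compound 4 is expected to land between compound 2 and compound 3, closer to compound 3, with an estimated 800 nM in this assay (range 300 nM to 2000 nM), which would mean a step of a 1.6-fold higher number from compound 3 to compound 4 (0.20 log units; within the scatter).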

Compound 4, half-maximal inhibitory concentration: 4780 nM
Estimate against measurement, compound 4: 6.0-fold (0.78 log units) below; measured number above the stated range.
By their numbers in this assay, from the lowest: compound 3; then compounds 2 and 1 (each within the scatter of the next); then compound 4.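

In this assay, the group on the aromatic nitrogen can push the number up as well as down: replacing 3-(trifluoromethyl)phenyl with 3-chloro-4-fluorophenyl gives a 9.4-fold higher number from compound 3 to compound 4 (0.97 log units; beyond the scatter). The same group also compares poorly with the 2-fluorophenyl of compound 2, with a 2.3-fold higher number from compound 2 to compound 4 (0.36 log units; beyond the scatter), so among these three aryl groups, a halogen-bearing ring does not by itself give a low number. Nothing available accounts for this difference between the groups.

As far as these compounds go, the chlorine and the fluorine of compound 4 arrive together, so their separate contributions remain unknown, and a plain 3-chlorophenyl or 4-fluorophenyl group would help to separate them. Also open, from the compounds shown here alone, is how this position would respond to a ring carrying an amine or a carboxylic acid, or to a longer alkyl chain in place of the aryl ring.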